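Working notes: the step from compound 3 to compound 4

The compounds below may be only part of what the source reports. "The series", "measured", "known", "first", "only" and "open" are said of these compounds alone.

Measured in a functional assay on HeLa cells (Homo sapiens) for antiproliferative activity, read by MTT assay, with a stated time of 48 h; on this read-out higher numbers stand for weaker inhibition and lower numbers for stronger inhibition:
- compound 1 `COc1ccc(-c2cncc3[nH]c(=O)n(Cc4cc(OC)c(OC)c(OC)c4)c23)cc1O`: > 20000 nM (a limit)
- compound 2 `COc1ccc(-c2cncc3[nH]c(=O)n(Cc4cc(OC)c(OC)c(OC)c4)c23)cc1`: > 20000 nM (a limit)
- compound 3 `COc1ccc(-c2cc3c(cn2)[nH]c(=O)n3-c2cc(OC)c(OC)c(OC)c2)cn1`: 870 nM

Among the measured compounds shown here, compound 3 holds the only actual number, since the entries for compound 1 and compound 2 are limits and not numbers. Compound 4 `COc1ccc(-c2cc3c(cn2)[nH]c(=O)n3-c2cc(OC)c(OC)c(OC)c2)cc1C(=O)O` is not yet measured. It carries 3-carboxy-4-methoxyphenyl in place of 6-methoxypyridin-3-yl on an aromatic carbon.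

For the measured compounds named here, no measured step covers this change. The one available, a step that the two limits leave unreadable from compound 1 to compound 2, concerns another group and gives no size to carry over. What remains is the spread of values, with the limit of > 20000 nM in this assay, at which 2 of the 3 values shown sit. Against that background, and with compound 3 at 870 nM as the sole reference, a step toward weaker inhibition in this assay is expected, with wide uncertainty. The expected step is a 4.6-fold higher number from compound 3 to compound 4 (0.66 log units; beyond the scatter). For compound 4 the estimated value is 4000 nM, with an expected range of 900 nM to 20000 nM.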

Compound 4, half-maximal inhibitory concentration: 5990 nM
For compound 4 the middle estimate is 1.5-fold (0.18 log units) below the measured one, and the stated range covers the measured number.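

In this assay, this position gives the series its first readable step, a 6.9-fold higher number from compound 3 to compound 4 (0.84 log units; beyond the scatter), for 3-carboxy-4-methoxyphenyl in place of 6-methoxypyridin-3-yl; the earlier step between compound 1 and compound 2 cannot be read, since both of its values are limits. The position therefore accepts this larger group, with its carboxy group and all-carbon ring, while compound 4 still gives an actual number, though a weaker one than compound 3. Nothing measured for these compounds accounts for the size of the step.

The change swaps the ring and its substituents together. The data do not separate the part played by the ring nitrogen from the part played by the carboxy group. A plain 4-methoxyphenyl group, or a methyl ester or primary amide in place of the carboxylic acid, would be needed to divide the two.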